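Urea to amide: what a single change might do

The compounds below may be only part of what the source reports. "The series", "measured", "known", "first", "only" and "open" are said of these compounds alone.

Measured so far:
compound 1 `COc1cc(Cl)cc(-c2nn(-c3cccc(NC(=O)Nc4ccc(Cl)c(Cl)c4)c3)cc2-c2ccncc2)c1` — 3.51%
compound 2 `COc1cc(Cl)cc(-c2nn(-c3cccc(NC(=O)Nc4cccc(C(F)(F)F)c4)c3)cc2-c2ccncc2)c1` — 5.3%

In a functional assay on SK-MEL-5 cells (Homo sapiens) for inhibition, read by sulforhodamine B assay, with a stated time of 48 h, tested at 10 uM (on this read-out higher numbers stand for a weaker effect at the one concentration tested and lower numbers for a stronger effect), compound 1 gives 3.51% and compound 2 gives 5.3%. For the measured compounds named here, compound 2 stands beside compound 1, the only other measured compound, with the step of a number 1.8 percentage points higher from compound 1 to compound 2 (within the scatter) within the scatter. Compound 3 `COc1cc(Cl)cc(-c2nn(-c3cccc(NC(=O)c4cccc(C(F)(F)F)c4)c3)cc2-c2ccncc2)c1` differs from compound 2 by 3-(trifluoromethyl)phenyl in place of (3-(trifluoromethyl)phenyl)amino on a carbonyl carbon. Going by the values given here, no measured step touches this change; the one known step concerns a different part of the molecule. The expectation therefore rests on compound 2 alone, with wide uncertainty, and the step of a number 3.7 percentage points higher from compound 2 to compound 3 (within the scatter) is estimated. Compound 3 is expected to give 9%, within 1% to 35%.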

Compound 3, a percentage reported as activity, at one concentration (the size of the read-out at that concentration, not a potency): 70.7%
Compound 3: middle estimate off by 61.7 percentage points, on the low side; the whole stated range lies below it.
By their numbers in this assay, from the lowest: compounds 1 and 2 (each within the scatter of the next); then compound 3.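

Replacing (3-(trifluoromethyl)phenyl)amino with 3-(trifluoromethyl)phenyl on the carbonyl carbon gives, in this assay, a number 65.4 percentage points higher from compound 2 to compound 3 (beyond the scatter), which means a much weaker effect. The change from the urea of compound 1 points the same way, with a number 67.2 percentage points higher from compound 1 to compound 3 (beyond the scatter). So in these compounds, the nitrogen on the carbonyl carbon counts for far more than the difference between the aryl groups of compound 1 and compound 2. Nothing available explains this loss of effect. On these data alone, whether the nitrogen or its hydrogen matters stays open; a methyl group on that nitrogen, or a carbamate oxygen in its place, could separate the two.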